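Fluoro on the methoxy ring of compound 2

The source may report more compounds than this note shows. Statements on the series, on what has been measured and on what is new or still open speak of the compounds shown alone.

Measured in a functional assay on MDA-MB-468 cells (Homo sapiens) for antiproliferative activity; on this read-out lower numbers stand for stronger inhibition of growth and higher numbers for weaker inhibition of growth
compound 1 `Oc1ccc(-c2nc3ccccc3s2)cc1O` gives 220 nM
compound 2 `COc1ccc(-c2nc3cc(F)ccc3s2)cc1` gives 330 nM

Compound 2 and compound 1 lie within the usual scatter of each other, so their two numbers show no real gap. Compound 3 `COc1ccc(-c2nc3cc(F)ccc3s2)cc1F` has fluoro in place of hydrogen on an aromatic carbon, ortho to a methoxy group fluoro in place of hydrogen on an aromatic carbon on an otherwise unchanged structure. Going by the values given here, no measured step covers this change, so no shift beyond the scatter is expected in this assay and neither direction is favoured. The expected move is small, with a 1.2-fold lower number from compound 2 to compound 3 (0.07 log units; within the scatter) as the estimate. For compound 3 the estimated value is 280 nM with 70 nM to 1000 nM as the expected range.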

Compound 3, concentration for 50% growth inhibition: 640 nM
Beside the measured number, compound 3's estimate is 2.3-fold (0.36 log units) below it, and the stated range covers the measured number.
By their numbers in this assay, from the lowest: compounds 1, 2 and 3 (each within the scatter of the next, the first and the last beyond it).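

Going by these compounds alone, the only single-place step shows that in this assay fluoro in place of hydrogen on an aromatic carbon, ortho to a methoxy group, gives a 1.9-fold higher number from compound 2 to compound 3 (0.29 log units; within the scatter) and so no real shift. This position therefore accepts fluoro without a change that can be told from the scatter. No measurement shown bears on the reason for this result.

As far as these compounds go, whether an amine or a carboxylic acid at this position would move the number beyond the scatter remains open. Also open, from the compounds shown here alone, is whether fluoro here would behave alike without the other fluoro on the shared core.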